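Five-membered ring in place of six on the carbonyl

A few compounds are considered here, and "the series" means these few. Any claim that something is new, unique, unknown or untested is made for them only; others in the source may bear on it.

Two compounds share one core and differ only in the ring attached to the carbonyl carbon. Compound 1 `COc1ccc(-c2cc3ccccc3nc2/C=C/C(=O)c2ccc(O)cc2)cc1` carries a 4-hydroxyphenyl there and, in a functional assay on A549 cells (Homo sapiens) for antiproliferative activity, read by XTT assay, with a stated time of 72 h (a higher number here means a weaker inhibitor, a lower number a stronger inhibitor), compound 1 gives 7440 nM. Compound 2 `COc1ccc(-c2cc3ccccc3nc2/C=C/C(=O)c2ccccn2)cc1` carries a pyridin-2-yl instead and in this assay compound 2 gives 6140 nM. Of the two numbers that of compound 2 is the lower, yet the step of a 1.2-fold lower number from compound 1 to compound 2 (0.08 log units; within the scatter) lies within the scatter, so the two compounds cannot be told apart.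

Compound 3 `COc1ccc(-c2cc3ccccc3nc2/C=C/C(=O)c2ccc[nH]2)cc1` is not yet measured. It differs from compound 2 by 1H-pyrrol-2-yl in place of pyridin-2-yl on a carbonyl carbon. Going by the values given here, the only step that bears on the same position, the exchange of one aromatic ring for another on the carbonyl carbon, changed nothing beyond the scatter. For compound 3 the expected step in this assay is therefore a 1.0-fold lower number from compound 2 to compound 3 (0.01 log units; within the scatter), again within the scatter. The estimate for compound 3 is 6000 nM, with a range from 2500 nM to 14000 nM.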

Compound 3, half-maximal inhibitory concentration: > 10000 nM
Compound 3 was reported as a limit; the forecaster's own chance of this, stated with the estimate: 5%; middle value at least 1.6-fold (0.22 log units) from the limit.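

In this assay compound 3 is reported as a limit and not as a number, and it is the only compound shown that is: the limit of > 10000 nM in this assay, at which 1 of the 3 values shown sits. Only floors can be read from it, an at least 1.6-fold higher number from compound 2 to compound 3 (0.21 log units; that floor lies within the scatter) and an at least 1.3-fold higher number from compound 1 to compound 3 (0.12 log units; that floor lies within the scatter), so the true size of either step is unknown and could be small or large. Going by these compounds alone, until now the one exchange on this carbonyl carbon, between two six-membered aromatic rings, stayed within the scatter, whereas the five-membered 1H-pyrrol-2-yl gives a result that can no longer be placed on the scale.

The 1H-pyrrol-2-yl changes ring size and brings a hydrogen-bond donor at once, so the compounds shown cannot separate these two differences. On these data alone, a furan-2-yl or a 1-methylpyrrol-2-yl on the same carbonyl carbon would bear on that question, and how either would read remains open.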